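From methyl to 4-fluorophenyl on the sulfonyl sulfur

The source may hold more compounds than are shown below. What is called first, only, known or untested is meant among the compounds shown, and "the series" means these compounds.

Compound 1 `CS(=O)(=O)N1CCC2(CC1)OOC1(CCCC1)OO2` gives > 100 ug/mL
Compound 2 `CCS(=O)(=O)N1CCC2(CC1)OOC1(CCCCCC1)OO2` gives > 100 ug/mL
Compound 3 `O=S(=O)(CCCCl)N1CCC2(CC1)OOC1(CCCCC1)OO2` gives > 100 ug/mL

All three compounds were tested in a functional assay on Huh-7 cells (Homo sapiens) for cytotoxicity, read by MTT assay, with a stated time of 72 h (a lower number here means that less compound is tolerated, a higher number that more compound is tolerated), and none of them gave a number. The whole set stands at one ceiling, namely the limit of > 100 ug/mL in this assay, at which 3 of the 3 values shown sit, and no exact reading. In this assay compound 1 gives > 100 ug/mL as its result, which is a limit and not a number.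

The next compound to be read is compound 4 `O=S(=O)(c1ccc(F)cc1)N1CCC2(CC1)OOC1(CCCC1)OO2` and it keeps the core of compound 1. Going by the values given here, the one change is 4-fluorophenyl in place of methyl on a sulfonyl sulfur and it amounts to 4-fluorophenyl in place of methyl on a sulfonyl sulfur. Among the compounds with values here, no measured pair isolates a change at this place, and the entering ring has no counterpart among the three compounds tested. The expectation therefore rests on the limits alone, and compound 1 with its > 100 ug/mL is the starting point. No step beyond the scatter is expected in this assay, though any shift that does appear is expected to mean that less compound is tolerated. The estimated change is a number no higher from compound 1 to compound 4 (the limit leaves the size open) in size. A further limit in place of a number is quite likely. For compound 4 the estimate is 100 ug/mL as the expected value, with an expected range from 40 ug/mL to 200 ug/mL for the measurement.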

Compound 4, half-maximal cytotoxic concentration: > 100 ug/mL
Compound 4: a limit, no number (the forecaster's own chance of this, stated with the estimate: 65%); the middle value lies on the limit itself.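

In this assay compound 4 gives > 100 ug/mL as a limit and not a number. Going by these compounds alone, no step from compound 1 to compound 4 can be read, because both stand at the same ceiling: the limit of > 100 ug/mL in this assay, at which 4 of the 4 values shown sit.

The compounds shown leave open how much of any of them these cells tolerate, and whether 4-fluorophenyl in place of methyl on a sulfonyl sulfur changes that at all.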